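The source may report more compounds than this note shows. Statements on the series, on what has been measured and on what is new or still open speak of the compounds shown alone.

Compound 1 `OC[C@H]1O[C@@H](n2cnc3c(COc4ccccc4)ncnc32)[C@H](O)[C@@H]1O`: > 100000 nM
Compound 2 `O=c1ccccn1Cc1ncnc2c1ncn2[C@@H]1O[C@H](CO)[C@@H](O)[C@H]1O`: > 100000 nM
Compound 3 `CC(=O)N(Cc1ncnc2c1ncn2[C@H]1C[C@H](O)[C@@H](CO)O1)C1CCCCC1`: > 100000 nM

In a functional assay on Huh-7 cells (Homo sapiens) for cytotoxicity, read by MTT assay, with a stated time of 3 days (on this read-out higher numbers stand for lower toxicity in this test and lower numbers for higher toxicity in this test), compound 1 gives > 100000 nM, a limit of the assay rather than a number. Compound 2 likewise gives > 100000 nM, which is a limit. Compound 3 gives > 100000 nM, also a limit. Compound 2 thus stands at the limit where the whole set sits, (the limit of > 100000 nM in this assay, at which 3 of the 3 values shown sit), and no ordering among the three can be read. The step that the two limits leave unreadable from compound 1 to compound 2 is accordingly unreadable. Compound 4 `CN(Cc1ncnc2c1ncn2[C@@H]1O[C@H](CO)[C@@H](O)[C@H]1O)c1ccccc1` is not yet measured; it differs from compound 2 by a group of 8 heavy atoms (7 carbon, 1 nitrogen; one six-membered aromatic ring of carbon only) in place of a group of 7 heavy atoms (5 carbon, 1 nitrogen, 1 oxygen; one six-membered aromatic ring with 1 hetero atom), on a saturated chain carbon bound to an aromatic carbon. For the measured compounds named here, only that unreadable step bears on this exchange, so no step beyond the scatter can be read or expected in this assay. The expected step is a step that the limit leaves unreadable from compound 2 to compound 4. Compound 4 is estimated at 150000 nM, between 50000 nM and 500000 nM, most likely reported again as a limit.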

Compound 4, half-maximal cytotoxic concentration: 21000 nM
For compound 4 the middle estimate is 7.1-fold (0.85 log units) above the measured one, and the stated range ends above it.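

In this assay compound 4 is the only compound shown that gives a number rather than a limit: the limit of > 100000 nM in this assay, at which 3 of the 4 values shown sit. Methyl(phenyl)amino on this saturated chain carbon bound to an aromatic carbon thus brings an at least 4.7-fold lower number from compound 2 to compound 4 (0.67 log units; beyond the scatter), and in place of phenoxy it brings an at least 4.7-fold lower number from compound 1 to compound 4 (0.67 log units; beyond the scatter). Both steps start from a limit, so they show that the group at this place can move the read-out toward higher toxicity in this test, but not by how much.

Going by these compounds, what a piperidine, a primary amine or a longer chain would give at this place remains open. So does whether methyl(phenyl)amino would have the same effect on the core of compound 3.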